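A Further Chain Step in a Sulfoxide Isothiocyanate Series

The source may report more compounds than this note shows. Statements on the series, on what has been measured and on what is new or still open speak of the compounds shown alone.

Compound 1 `CC(C)[S+]([O-])CCCCN=C=S`: 10400 nM
Compound 2 `CC(C)[S+]([O-])CCCCCN=C=S`: 7750 nM
Compound 3 `CC(C)[S+]([O-])CCCCCCN=C=S`: not yet measured

For the measured compounds named here, in a functional assay on A549 cells (Homo sapiens) for cytotoxicity, read by MTT assay, with a stated time of 72 h (on this read-out lower numbers stand for stronger inhibition and higher numbers for weaker inhibition), compound 2 gives 7750 nM, within the usual scatter of compound 1, the only other measured compound. Compound 3 differs from compound 2 by a group of 4 heavy atoms (2 carbon, 1 nitrogen, 1 sulfur; no ring) in place of a group of 3 heavy atoms (1 carbon, 1 nitrogen, 1 sulfur; no ring), on a saturated chain carbon, five bonds along the chain from a sulfur. Going by the values given here, the one measured step of this kind is a 1.3-fold lower number from compound 1 to compound 2 (0.13 log units; within the scatter), and it took place four bonds along the chain from a sulfur. On that single step, no change beyond the scatter is expected in this assay. The expected step is a 1.2-fold lower number from compound 2 to compound 3 (0.08 log units; within the scatter). The estimate for compound 3 is 6500 nM. The expected range for compound 3 runs from 3500 nM to 11500 nM.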

Compound 3, half-maximal inhibitory concentration: 12000 nM
The estimate for compound 3 lay 1.8-fold (0.27 log units) below the measured number, and the stated range ends below it.
By their numbers in this assay, from the lowest: compounds 2, 1 and 3 (each within the scatter of the next).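

In this assay the step at five bonds along the chain from a sulfur is a 1.5-fold higher number from compound 2 to compound 3 (0.19 log units; within the scatter) and, like the step at four bonds, gives no change that can be told from the scatter. Lengthening the chain at either place therefore shows no trend, and the sign of the earlier step did not carry over to this one. No other measurement bears on this result. On these data alone, whether a longer chain, or an amine or a carboxylic acid in place of the isothiocyanate, would move the number beyond the scatter remains open.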